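Chloro in place of hydrogen: acid dissociation notes

The source may hold more compounds than are shown below. What is called first, only, known or untested is meant among the compounds shown, and "the series" means these compounds.

Compound 1 `Fc1ccc(Cc2ccc3c(NCCCNCc4ccco4)ccnc3c2)cc1` and compound 2 `Fc1ccc(Cc2ccc3c(NCCCNCc4ccco4)ccnc3c2)c(Cl)c1` share one core. In a physicochemical assay for acid dissociation, compound 1 gives 9.47 and compound 2 gives 9.47; the step of no change at the digits printed from compound 1 to compound 2 (within the scatter) accompanies (chloro in place of hydrogen on an aromatic carbon). Compound 3 `COc1ccc(F)cc1CNCCCNc1ccnc2cc(Oc3ccccc3)ccc12` rests on a different core; the difference between the two cores is not broken down here. In this assay compound 3 gives 9.28, within the scatter of compound 1 and compound 2. Compound 4 `COc1ccc(F)cc1CNCCCNc1ccnc2cc(Oc3ccc(Cl)cc3)ccc12` awaits measurement; it differs from compound 3 by chloro in place of hydrogen on an aromatic carbon, the same kind of change as from compound 1 to compound 2, though there the chloro sits ortho to a large group and meta to a fluoro group, whereas here it sits para to a large group. The step of no change at the digits printed from compound 3 to compound 4 (within the scatter) is expected to be small, since the earlier step of no change at the digits printed from compound 1 to compound 2 (within the scatter) shows no change. Compound 4 is therefore estimated at 9.28, between 9 and 9.55.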

Compound 4, acid dissociation constant: 9.28
Beside the measured number, compound 4's estimate shows no gap at the digits printed; measured number inside the range.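

In this assay chloro in place of hydrogen on an aromatic carbon gives no change at the digits printed from compound 3 to compound 4 (within the scatter) on one core and no change at the digits printed from compound 1 to compound 2 (within the scatter) on the other core, so the change carries across these two cores with the same outcome. This rests on two pairs only, with the chloro para to a large group in the newer pair and in a different place in the earlier one, and it does not show that the outcome would hold on any further core or at any other place. No measurement in hand bears on why the number stays put.

Still open, from the compounds shown here alone, is whether an amine or a carboxylic acid in place of the chloro would carry across the two cores in the same way. A single pair for each of those groups on each core would settle this.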